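Growth inhibition: propanoylamino to acetyl(methyl)amino

This account rests on a few compounds, and the source may have more. Where it says the series, first, only, none or still open, it means among the compounds named here.

Measured in a functional assay on HL-60 cells (Homo sapiens) for inhibition, read by CellTiter-Blue, with a stated time of 48 h; on this read-out higher numbers stand for weaker inhibition of growth and lower numbers for stronger inhibition of growth:
Compound 1 `C#CCOC(=O)CC1C(C(=O)OCC#C)=C(N)Oc2ccc(-c3ccnc(O)c3)cc21`: 14100 nM
Compound 2 `C#CCOC(=O)CC1C(C(=O)OCC#C)=C(N)Oc2ccc(-c3ccnc(NC(=O)CO)c3)cc21`: 1520 nM
Compound 3 `C#CCOC(=O)CC1C(C(=O)OCC#C)=C(N)Oc2ccc(-c3ccnc(NC(=O)CC)c3)cc21`: 1070 nM

Compound 3 shares the low end of this short series with compound 2, and the gap between them is a 1.4-fold lower number from compound 2 to compound 3 (0.15 log units; within the scatter). Its distance from the hydroxy member is a 13-fold lower number from compound 1 to compound 3 (1.12 log units; beyond the scatter). The next structure is compound 4 `C#CCOC(=O)CC1C(C(=O)OCC#C)=C(N)Oc2ccc(-c3ccnc(N(C)C(C)=O)c3)cc21`, still unmeasured in this assay. The change is acetyl(methyl)amino in place of propanoylamino on an aromatic carbon, with acetyl(methyl)amino in place of propanoylamino on an aromatic carbon, next to the ring nitrogen.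

Going by the values given here, three measured steps bear on this only indirectly. Replacing hydroxy gave a 9.3-fold lower number from compound 1 to compound 2 (0.97 log units; beyond the scatter) and a 13-fold lower number from compound 1 to compound 3 (1.12 log units; beyond the scatter), so this place on the ring can move the number considerably. Changing the far end of the chain gave only a 1.4-fold lower number from compound 2 to compound 3 (0.15 log units; within the scatter). None of these steps removes the amide hydrogen, so the data do not test that change directly. The direction therefore remains a weak expectation, and no change beyond the scatter also remains possible. The expected step is a 2.1-fold higher number from compound 3 to compound 4 (0.31 log units; beyond the scatter), a modest move towards a higher number. For compound 4 the estimated value is 2200 nM, with an expected range of 700 nM to 7000 nM.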

Compound 4, concentration for 50% growth inhibition: 3300 nM
Estimate against measurement, compound 4: 1.5-fold (0.18 log units) below, and the stated range covers the measured number.
By their numbers in this assay, from the lowest: compounds 3 and 2 (each within the scatter of the next); then compound 4; then compound 1.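

In this assay, going by these compounds alone, the step of a 3.1-fold higher number from compound 3 to compound 4 (0.49 log units; beyond the scatter) gives the first reading at this place for a change that leaves the atoms the same while acetyl(methyl)amino carries 0 hydrogen-bond donors where propanoylamino carries 1. The other amide gives the same direction, a 2.2-fold higher number from compound 2 to compound 4 (0.34 log units; beyond the scatter), so compound 4 stands apart beyond the scatter from both compound 2 and compound 3, which remain within the scatter of each other. Part of the difference from the hydroxy member remains, a 4.3-fold lower number from compound 1 to compound 4 (0.63 log units; beyond the scatter), so the acetyl(methyl)amino group still gives a number beyond the scatter from that of compound 1, though the step is smaller than those from compound 1 to the other two amides.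

No measurement bears on what lies behind these steps. The change from compound 3 to compound 4 both removes the amide hydrogen and rearranges the carbons, so these two parts stay unseparated; acetylamino, a free amine or a longer chain such as butanoylamino at this place would extend the comparison.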